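This account rests on a few compounds, and the source may have more. Where it says the series, first, only, none or still open, it means among the compounds named here.

In a functional assay on PC-12 cells (Rattus norvegicus) for cytotoxicity, read by MTT assay, with stated times of 2 h and 24 h, tested at 5 uM (on this read-out lower numbers stand for a weaker effect and higher numbers for a stronger effect at the one concentration tested), compound 1 `Oc1cc(C(F)(F)F)ccc1-c1nc(-c2ccccc2O)n(-c2ccc(I)cc2)n1` gives 94.4%. Compound 2 `Oc1cc(C(F)(F)F)ccc1-c1nc(-c2ccccc2O)n(-c2ccc(OC(F)(F)F)cc2)n1` gives 84.9% in this assay. Within the data shown here, the single step that joins these two compounds, a number 9.5 percentage points lower from compound 1 to compound 2 (within the scatter), does not exceed the scatter, so compound 2 stands alongside compound 1 rather than apart from it; the two numbers are indistinguishable within the reproducibility of this kind of measurement.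

Compound 3 `Oc1cc(C(F)(F)F)ccc1-c1nc(-c2ccccc2O)n(-c2cccc(Cl)c2)n1` has not yet been measured in this assay. It differs from compound 2 in one place: 3-chlorophenyl in place of 4-(trifluoromethoxy)phenyl on an aromatic nitrogen.

Among the measured compounds shown here, no measured step exchanges the whole group on that aromatic nitrogen for a 3-chlorophenyl. For the measured compounds named here, the only step at hand, a number 9.5 percentage points lower from compound 1 to compound 2 (within the scatter), swaps one substituent of the phenyl on that nitrogen for another and stays within the scatter. On this basis no step beyond the scatter is expected from compound 2 to compound 3 in this assay, and the expected step is written as a number 2.1 percentage points higher from compound 2 to compound 3 (within the scatter). Compound 3 is therefore estimated at 87% in this assay, with an expected range from 74% to 98%.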

Compound 3, a percentage reported as activity, at one concentration (the size of the read-out at that concentration, not a potency): 92.7%
The estimate for compound 3 lay 5.7 percentage points below the measured number; low and high end bracket the measured number.
By their numbers in this assay, from the lowest: compounds 2, 3 and 1 (each within the scatter of the next).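

On the aromatic nitrogen of the shared core, compound 3 carries a 3-chlorophenyl, where compound 1 carries a 4-iodophenyl and compound 2 a 4-(trifluoromethoxy)phenyl. In this assay neither exchange goes beyond the scatter (a number 7.8 percentage points higher from compound 2 to compound 3 (within the scatter); a number 1.7 percentage points lower from compound 1 to compound 3 (within the scatter)), so the earlier finding now extends from a swap of one substituent for another to a substituent of a different kind at a different place on the phenyl. The exchange from compound 2 to compound 3 also replaces a group of 11 heavy atoms and 1 hydrogen-bond acceptor with one of 7 heavy atoms and no hydrogen-bond acceptor, and for these compounds that difference does not separate the read-outs.

From the compounds shown here alone, all three compounds keep a halogen-bearing or fluorine-bearing phenyl on that nitrogen, so it remains open whether an unsubstituted phenyl, a benzyl group, a pyridine, or a phenyl bearing an amine or a carboxylic acid would read the same. Each compound is also known here at one concentration only, which leaves any comparison of potency open. Nothing available here accounts for these numbers.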